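From cyclopropylmethoxy to ethoxy: expected protein binding of compound 4

The source may hold more compounds than are shown below. What is called first, only, known or untested is meant among the compounds shown, and "the series" means these compounds.

Compound 1 `O=C(O)CCn1c(=O)oc2cc(Cl)c(Cl)cc21` gives 91.7%
Compound 2 `O=C(O)CCn1c(=O)oc2cc(OCC3CC3)c(Cl)cc21` gives 90.2%
Compound 3 `C[C@@H](Oc1cc2onc(CCC(=O)O)c2cc1Cl)c1ccc(Cl)cn1` gives 99.7%

All three compounds were measured in an ADME assay on the whole organism (plasma, Rattus norvegicus, strain Han-Wistar) for protein binding, read by LC-MS, at a dose of 1 mg/kg by the intravenous route. Compound 2 stands level with compound 1 within the scatter, while compound 3 lies beyond the scatter from compound 2, with more of it bound.

The next compound is compound 4 `CCOc1cc2oc(=O)n(CCC(=O)O)c2cc1Cl`, and the change that leads to it is methyl in place of cyclopropyl on a saturated chain carbon bound to an oxygen on an aromatic ring. In words, this is methyl in place of cyclopropyl on a saturated chain carbon bound to an oxygen on an aromatic ring, so cyclopropylmethoxy becomes ethoxy. Among the measured compounds shown here, only one measured step bears on this, a 1.2-fold higher unbound fraction from compound 1 to compound 2 (0.07 log units; within the scatter), where cyclopropylmethoxy took the place of chloro on an aromatic carbon. That step is small. For the measured compounds named here, compound 3 does not share the core of compound 1 and offers no step for this change. With so little to go on, no change beyond the scatter is expected in this assay, and any drift would be slight, towards more free compound. The expected step is a 1.1-fold higher unbound fraction from compound 2 to compound 4 (0.05 log units; within the scatter). Compound 4 is estimated at 89%, with an expected range of 82% to 94%.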

Compound 4, plasma protein binding: 81.6%
Compound 4: middle estimate off by 1.7-fold (0.22 log units) (unbound fraction), on the low side; measured number outside the range, below it.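

In this assay, replacing cyclopropyl with methyl on a saturated chain carbon bound to an oxygen on an aromatic ring gives a 1.9-fold higher unbound fraction from compound 2 to compound 4 (0.27 log units; within the scatter), so compound 2 and compound 4 stand level at this position, and removing the three-membered ring does not take the step beyond the scatter. Measured against the chloro group on the aromatic carbon, however, ethoxy gives a 2.2-fold higher unbound fraction from compound 1 to compound 4 (0.35 log units; beyond the scatter), a modest step beyond the scatter, whereas cyclopropylmethoxy gave a 1.2-fold higher unbound fraction from compound 1 to compound 2 (0.07 log units; within the scatter), which stayed within it. The data shown offer nothing that explains these steps.

From the compounds shown here alone, it remains open how plasma protein binding would respond to a shorter group such as methoxy, a longer chain such as propoxy, or a chain ending in an amine on the same oxygen, and so whether the free fraction keeps shifting as the group changes. It is also open whether methyl in place of cyclopropyl would give a similar step on the core of compound 3, since the compounds shown offer no such pair on that core.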